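Anilino-triazole series: moving the methoxy group around

A few compounds are considered here, and "the series" means these few. Any claim that something is new, unique, unknown or untested is made for them only; others in the source may bear on it.

The shared core of compound 2, `N#Cc1c(Nc2cccc(Cl)c2)nc(SCc2cn(Cc3ccccc3Cl)nn2)nc1-c1ccccc1`, carries an arylamino group on a nitrogen on an aromatic ring. For the measured compounds named here, in a functional assay on MCF7 cells (Homo sapiens) for inhibition, read by MTT assay, with a stated time of 72 h (a lower number here means a stronger inhibitor, a higher number a weaker inhibitor), compound 2 gives 12000 nM, the highest of the two numbers so far; the nearest is compound 1, `COc1ccc(Nc2nc(SCc3cn(Cc4ccccc4Cl)nn3)nc(-c3ccccc3)c2C#N)cc1`, which in this assay gives 8050 nM. Going by the values given here, the only step between them, a 1.5-fold higher number from compound 1 to compound 2 (0.17 log units; within the scatter), stays within the scatter, so the two values show no separation.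

Compound 3, `COc1ccccc1Nc1nc(SCc2cn(Cc3ccccc3Cl)nn2)nc(-c2ccccc2)c1C#N`, is the next unmeasured member. Its difference from compound 2 is 2-methoxyphenyl in place of 3-chlorophenyl on a nitrogen on an aromatic ring. Among the compounds with values here, the one step that bears on it, a 1.5-fold higher number from compound 1 to compound 2 (0.17 log units; within the scatter), swapped a 4-methoxyphenyl for a 3-chlorophenyl at the same place without moving beyond the scatter; compound 3 brings back a methoxyphenyl, though with the methoxy group at the 2-position rather than the 4-position. On that evidence the expected step of a 1.3-fold lower number from compound 2 to compound 3 (0.12 log units; within the scatter) is small and, if anything, toward the number of compound 1. Compound 3 is therefore estimated at 9000 nM in this assay, with a range from 3500 nM to 25000 nM.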

Compound 3, half-maximal inhibitory concentration: 6170 nM
For compound 3 the middle estimate is 1.5-fold (0.16 log units) above the measured one; measured number inside the range.
By their numbers in this assay, from the lowest: compounds 3, 1 and 2 (each within the scatter of the next).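

In this assay, the methoxy group can now be compared directly at this place: 2-methoxyphenyl in place of 4-methoxyphenyl gives a 1.3-fold lower number from compound 1 to compound 3 (0.12 log units; within the scatter), so these two methoxyphenyl groups show no separation. The second new comparison, 2-methoxyphenyl in place of 3-chlorophenyl, gives a 1.9-fold lower number from compound 2 to compound 3 (0.29 log units; within the scatter), which is also within the scatter, and with the earlier step this means that all three pairs among compounds 1, 2 and 3 are now unresolved, so the three groups on this nitrogen cannot be ranked. No measurement at hand offers an explanation for these values.

The compounds shown carry only a 3-chlorophenyl and two methoxyphenyl groups at this place, so it remains open whether a different kind of group, such as a cyclohexyl, or a phenyl bearing a carboxylic acid or a dimethylamino group, would separate from them in this assay. From the compounds shown here alone, all three compounds also keep the nitrile on the shared core, so it remains open whether the same lack of separation would hold with an amide there.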